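A few compounds are considered here, and "the series" means these few. Any claim that something is new, unique, unknown or untested is made for them only; others in the source may bear on it.

Measured so far:
- compound 1 `COc1ccc(C2=C(c3cc(OC)c(OC)c(OC)c3)C(=O)CC2C)cc1C(=O)O` — > 100 ug/mL
- compound 2 `COc1ccc(C2=C(c3cc(OC)c(OC)c(OC)c3)C(=O)C(O)C2)cc1NC(=O)c1ccccc1` — > 100 ug/mL
- compound 3 `O/N=C1/CC(O)C(c2ccccc2)=C1c1ccccc1` — > 100 ug/mL

In an ADME assay on L132 cells (Homo sapiens) for cytotoxicity, read by MTT assay, with a stated time of 72 h (a higher number here means a weaker inhibitor, a lower number a stronger inhibitor), compound 1 gives > 100 ug/mL, which is a limit of the assay and not a number. In this assay compound 2 gives > 100 ug/mL, also a limit. In this assay compound 3 gives > 100 ug/mL, again a limit. Compound 2 therefore stands where every compound here stands: at the limit of > 100 ug/mL in this assay, at which 3 of the 3 values shown sit, so none of the three can be told apart from the others by these numbers.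

Compound 4 `COc1ccc(C2=C(c3cc(OC)c(OC)c(OC)c3)C(=O)C(O)C2)cc1OC(C)C` is the next compound. It differs from compound 2 in one place: isopropoxy in place of benzamido on an aromatic carbon.

Going by the values given here, no two measured compounds differ in just one place, so no measured step shows what such a change does in this assay. With every value shown sitting at the limit, the step from compound 2 to compound 4 is expected to be none beyond the scatter, and compound 4 is expected to come out at the limit as well. Compound 4 is estimated at 150 ug/mL, with a range from 60 ug/mL to 400 ug/mL; the expected step that the limit leaves unreadable from compound 2 to compound 4 is none beyond the scatter.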

Compound 4, half-maximal inhibitory concentration: > 100 ug/mL
Compound 4 gave a limit, no number (the forecaster's own chance of this, stated with the estimate: 85%); the middle value lies beyond the limit too.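

The step from compound 2 to compound 4 cannot be read, since both results are limits of the assay and not numbers: the limit of > 100 ug/mL in this assay, at which 4 of the 4 values shown sit.

The compounds shown leave open what actual value any of them has in this assay, and whether swapping one group on the shared core changes it.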